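A few compounds are considered here, and "the series" means these few. Any claim that something is new, unique, unknown or untested is made for them only; others in the source may bear on it.

Of the compounds shown here, three built on a shared core have been measured in an assay on isolated protein for agonist activity at Bile acid receptor (Homo sapiens), read by FRET; on this read-out higher numbers stand for an effect only at larger amounts of compound and lower numbers for an effect already at smaller amounts. Compound 1 `CC(C)n1nc(C(=O)O)cc1[C@@H]1C[C@H]1c1ccc(OCc2c(-c3c(Cl)cccc3Cl)noc2C2CC2)cc1Cl` gives 4 nM in this assay, the lowest of the three numbers. Compound 2 `O=C(O)c1cncc(N2CC(O)(c3ccc(OCc4c(-c5c(Cl)cccc5Cl)noc4C4CC4)cc3Cl)C2)c1` gives 7 nM in this assay, and the two values lie within the scatter of each other, so neither compound can be placed ahead of the other. Compound 3 `CS(=O)(=O)NC(=O)c1ccc(C2CC2c2ccc(OCc3c(-c4c(Cl)cccc4Cl)noc3C3CC3)cc2Cl)cc1` gives 90 nM in this assay, a number that stands beyond the scatter from that of compound 1 and is the furthest from it among the three.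

Compound 4 `O=C(O)c1cccc([C@@H]2C[C@H]2c2ccc(OCc3c(-c4c(Cl)cccc4Cl)noc3C3CC3)cc2Cl)c1` has not yet been measured. It differs from compound 1 in one place: 3-carboxyphenyl in place of 3-carboxy-1-isopropyl-1H-pyrazol-5-yl on a saturated ring carbon. Within the data shown here, no pair among the measured compounds differs in exactly this way, so the size of the step cannot be read from a measured pair. What can be seen is that compound 1 and compound 2, each carrying a carboxylic acid on an aromatic ring, stay within the scatter of each other, while compound 3 gives a larger number. Compound 4 keeps a carboxylic acid on an aromatic ring, and the step is expected to be small in this assay, a modest rise in the number or none beyond the scatter: a 2.5-fold higher number from compound 1 to compound 4 (0.40 log units; beyond the scatter). Compound 4 is therefore estimated at 10 nM in this assay, with a range from 3 nM to 40 nM.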

Compound 4, half-maximal effective concentration: 18 nM
For compound 4 the middle estimate is 1.8-fold (0.26 log units) below the measured one; measured number inside the range.
By their numbers in this assay, from the lowest: compounds 1 and 2 (each within the scatter of the next); then compound 4; then compound 3.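

In this assay, the group on the saturated ring carbon of the three-membered ring turns out to matter even when a carboxylic acid on an aromatic ring is kept: the change gives a 4.5-fold higher number from compound 1 to compound 4 (0.65 log units; beyond the scatter), a modest step that still lies beyond the scatter. A carboxylic acid on an aromatic ring at this place is therefore not enough by itself to hold the number at that of compound 1, and of this pair the 3-carboxy-1-isopropyl-1H-pyrazol-5-yl group gives the lower number. No measurement shown here accounts for the step.

The change replaces the five-membered ring with its two nitrogens and removes the isopropyl group in a single move, so the compounds shown cannot separate the contribution of the ring from that of the isopropyl group. From the compounds shown here alone, a pyrazole carrying methyl in place of isopropyl, or a pyridine ring bearing the carboxylic acid, would address that question, and it also remains open how a tetrazole in place of the carboxylic acid would fare at this position.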